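The source may hold more compounds than are shown below. What is called first, only, known or untested is meant among the compounds shown, and "the series" means these compounds.

Of the compounds shown here, three of one shared core have been tested in an ADME assay on HEK293 cells for agonist activity at Toll-like receptor 8 (Homo sapiens), read by a luciferase reporter, with a stated time of 6 h; a higher number here means that more compound is needed for the effect, a lower number that less compound is needed. Compound 1 `CCNc1nc(N)nc2ccccc12` gives 0.77 uM. Compound 2 `CCCCNc1nc(N)nc2ccc(C(C)O)cc12`, which carries a longer chain on the amine and a hydroxyethyl group on the aromatic ring, gives 5.8 uM. Compound 3 `CCCCNc1nc(N)nc2cccc(OC)c12`, with the same longer chain and a methoxy group on the aromatic ring, gives 0.1 uM, the lowest of the three numbers; its distance from compound 1 and its larger distance from compound 2 both lie beyond the scatter of the measurement.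

Compound 4 `CCCCNc1nc(N)nc2cccc(OCc3cccnc3)c12` has not yet been measured in this assay. It differs from compound 3 in one place: pyridin-3-yl in place of hydrogen on a saturated chain carbon bound to an oxygen on an aromatic ring. For the measured compounds named here, no pair of measured compounds here shows the effect of such an addition on an oxygen-bound chain, so the expectation rests on the position of compound 3 alone. The group that enters is larger than what it replaces, and the three measured numbers give no guide to how much room such an addition is tolerated. For compound 4 a small step upward, close to the scatter, is expected, a 3.0-fold higher number from compound 3 to compound 4 (0.48 log units; beyond the scatter). The value estimated for compound 4 in this assay is therefore 0.3 uM, with a range from 0.05 uM to 2 uM.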

Compound 4, minimum effective concentration: 0.53 uM
The estimate for compound 4 lay 1.8-fold (0.25 log units) below the measured number, and the stated range covers the measured number.
By their numbers in this assay, from the lowest: compound 3; then compounds 4 and 1 (each within the scatter of the next); then compound 2.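

For the compounds shown here, compound 3 and compound 4 are the first pair here to differ in one place, and in this assay they show that the methoxy group can become (pyridin-3-yl)methoxy with a cost in concentration, a 5.3-fold higher number from compound 3 to compound 4 (0.72 log units; beyond the scatter), that is modest for such a large addition. The six-membered aromatic ring on the saturated chain carbon bound to an oxygen on an aromatic ring therefore does not abolish the effect, and compound 4 still gives 0.53 uM in the same test. Nothing available here accounts for the rise in the number.

This single step cannot separate the contribution of the added ring carbons from that of the ring nitrogen, so phenyl, pyridin-2-yl or pyridin-4-yl in the same place could each give a different number. It also leaves open how the number would respond to a small step such as ethoxy, to a longer chain between the oxygen and the ring, or to an amine on the chain.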